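This account rests on a few compounds, and the source may have more. Where it says the series, first, only, none or still open, it means among the compounds named here.

Values in a functional assay on HL-60 cells (Homo sapiens) for antiproliferative activity, read by MTT assay, with a stated time of 72 h; on this read-out lower numbers stand for stronger inhibition and higher numbers for weaker inhibition:
- compound 1 `COc1ccc(-c2ncnn2-c2cc(OC)c(OC)c(OC)c2)cc1`: 120 nM
- compound 2 `COc1cc(-n2ncnc2-c2ccc(OC(C)C)cc2)cc(OC)c1OC`: 700 nM
- compound 3 `COc1ccccc1-c1ncnn1-c1cc(OC)c(OC)c(OC)c1`: > 10000 nM (a limit, not a number)

Compound 3 stands at the limit of > 10000 nM in this assay, at which 1 of the 3 values shown sits. Any step away from compound 3 is therefore known from one side only.

Next in the series is compound 4 `COc1cc(-n2ncnc2-c2ccc(F)cc2)cc(OC)c1OC`, not yet measured. The change is 4-fluorophenyl in place of 2-methoxyphenyl on an aromatic carbon.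

Among the measured compounds shown here, two measured steps bear on this change. The closer one is an at least 83-fold higher number from compound 1 to compound 3 (1.92 log units; beyond the scatter), a large step that concerns the same aromatic carbon, with 2-methoxyphenyl in place of 4-methoxyphenyl. The other is a 5.8-fold higher number from compound 1 to compound 2 (0.77 log units; beyond the scatter), a modest step, with isopropyl in place of methyl on an oxygen. Among these three compounds, the two with an alkoxy group in the 4-substituted phenyl give numbers, and compound 3 gives only a limit. For the measured compounds named here, no measured step replaces that alkoxy group with fluorine, so the range stays wide.

A large step towards a lower number is expected in this assay, probably not quite recovering the value of compound 1. The expected step is an at least 25-fold lower number from compound 3 to compound 4 (1.39 log units; beyond the scatter). The estimate for compound 4 is 400 nM, with an expected range of 80 nM to 2500 nM.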

Compound 4, half-maximal inhibitory concentration: > 10000 nM
Compound 4: a limit, no number; the forecaster's own chance of this, stated with the estimate: 7%; at least 25-fold (1.39 log units) between middle value and limit.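

In this assay compound 4 gives > 10000 nM, which is a limit and not a number. Compound 3 also stands at a limit, so the step between these two compounds cannot be read: the limit of > 10000 nM in this assay, at which 2 of the 4 values shown sit.

Among the compounds shown here, what the result adds is the first replacement of the alkoxy group by fluorine on the phenyl ring at this aromatic carbon: fluoro in place of methoxy gives an at least 83-fold higher number from compound 1 to compound 4 (1.92 log units; beyond the scatter), and fluoro in place of isopropoxy gives an at least 14-fold higher number from compound 2 to compound 4 (1.15 log units; beyond the scatter). Moving the methoxy group in 2-methoxyphenyl had already lost a number, and now 4-fluorophenyl shows that a substituent at the 4-position of the phenyl ring does not by itself keep one, since among the compounds shown only the methoxy and isopropoxy groups there give numbers.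

On these data alone, it remains open whether a 4-ethoxyphenyl, 4-hydroxyphenyl, 4-aminophenyl or 4-chlorophenyl group at this carbon would give a number, and so whether the oxygen of the alkoxy group matters or some other feature of it. As far as these compounds go, how far compound 3 and compound 4 lie beyond the limit, and whether they differ at all, also stays open.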